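Furan in Place of Benzofuran at the Nucleoside Core

The source may report more compounds than this note shows. Statements on the series, on what has been measured and on what is new or still open speak of the compounds shown alone.

Compound 2 `Nc1nc(N)c2c(-c3cc4ccccc4o3)cn([C@@H]3O[C@H](CO)[C@@H](O)[C@H]3O)c2n1` stands at a limit: in a functional assay on CCRF-CEM cells (Homo sapiens), read by MTT assay, with a stated time of 72 h (a higher number here means a weaker inhibitor, a lower number a stronger inhibitor), compound 2 gives > 20000 nM, a limit of the assay rather than a number. Going by the values given here, compound 1 `COc1nc(N)nc2c1c(-c1cc3ccccc3o1)cn2[C@@H]1O[C@H](CO)[C@@H](O)[C@H]1O` is the one member of this set with a numerical value, giving 12700 nM in this assay. Compound 3 `Cc1nc(N)c2c(-c3cc4ccccc4o3)cn([C@@H]3O[C@H](CO)[C@@H](O)[C@H]3O)c2n1` gives > 20000 nM in this assay, which is again a limit. The two measured steps, an at least 1.5-fold higher number from compound 1 to compound 2 (0.19 log units; that floor lies within the scatter) and a step that the two limits leave unreadable from compound 2 to compound 3, both end at a limit (the limit of > 20000 nM in this assay, at which 2 of the 3 values shown sit), so neither gives a readable size. Compound 4 `Nc1nc(N)c2c(-c3ccco3)cn([C@@H]3O[C@H](CO)[C@@H](O)[C@H]3O)c2n1` differs from compound 2 by furan-2-yl in place of 1-benzofuran-2-yl on an aromatic carbon. Neither measured step touches the 1-benzofuran-2-yl group, so the numbers shown say nothing for or against this change. Compound 2 sits at a limit, > 20000 nM. Compound 4 is therefore expected to stay there, with an estimate of 30000 nM and a range from 8000 nM to 100000 nM. The expected step that the limit leaves unreadable from compound 2 to compound 4 is thus none beyond the scatter.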

Compound 4, half-maximal inhibitory concentration: > 20000 nM
Compound 4: a limit, no number; the forecaster's own chance of this, stated with the estimate: 80%; the middle value is on the limit's open side.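

In this assay compound 4 gives > 20000 nM, which is a limit and not a number. Going by these compounds alone, compound 2 also stands at a limit, so no step between the two can be read. The compounds shown leave open whether furan-2-yl or 1-benzofuran-2-yl gives the lower number.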